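This account rests on a few compounds, and the source may have more. Where it says the series, first, only, none or still open, it means among the compounds named here.

Measured compounds:
Compound 1 `COc1cncc(-c2cccc(-c3cn4cccc(C(N)=O)c4n3)c2)c1`: in a physicochemical assay for solubility, in phosphate buffer, with a stated time of 24 h, at pH 7.4 (a higher number here means a more soluble compound, a lower number a less soluble compound), compound 1 gives < 1000 nM, which is a limit of the measurement and not a number.
Compound 2 `NC(=O)c1cccn2cc(-c3cccc(-c4cncc(OC[C@H]5CCCO5)c4)c3)nc12`: in this assay compound 2 gives 5300 nM.
Compound 3 `COc1cncc(-c2cccc(-c3cn4ccnc(C(N)=O)c4n3)c2)c1`: in this assay compound 3 gives 10000 nM.

Compound 1 and compound 2 differ by oxolan-2-yl in place of hydrogen on a saturated chain carbon bound to an oxygen on an aromatic ring. In this assay this gives an at least 5.3-fold higher number from compound 1 to compound 2 (0.72 log units; beyond the scatter), with the caveat that the starting point is only known as the limit of < 1000 nM in this assay, at which 1 of the 3 values shown sits. The difference between the core of compound 1 and the core of compound 3 is not broken down here. The values of compound 2 and compound 3 in this assay lie within the scatter of each other, so no order between them is claimed.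

Compound 4 `NC(=O)c1nccn2cc(-c3cccc(-c4cncc(OC[C@H]5CCCO5)c4)c3)nc12` is not yet measured. It differs from compound 3 by oxolan-2-yl in place of hydrogen on a saturated chain carbon bound to an oxygen on an aromatic ring, the same change as from compound 1 to compound 2, at the same place. Because the earlier step gave an at least 5.3-fold higher number from compound 1 to compound 2 (0.72 log units; beyond the scatter), a rise of similar kind is expected for compound 4, though that earlier step rests on a limit. The expected step is a 2.5-fold higher number from compound 3 to compound 4 (0.40 log units; beyond the scatter). Compound 4 is estimated at 25000 nM in this assay, with a range of 8000 nM to 70000 nM.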

Compound 4, solubility: 40000 nM
Estimate against measurement, compound 4: 1.6-fold (0.20 log units) below; the range from low to high includes it.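

In this assay, oxolan-2-yl in place of hydrogen on a saturated chain carbon bound to an oxygen on an aromatic ring gives a 4.0-fold higher number from compound 3 to compound 4 (0.60 log units; beyond the scatter), and on the core of compound 1 the same change gives an at least 5.3-fold higher number from compound 1 to compound 2 (0.72 log units; beyond the scatter), so the direction carries from one core to the other and none of the four compounds goes against it. The value of compound 1 is a limit and not a number, so the sizes of the two steps cannot be set against each other, because the earlier step has no fixed starting point: the limit of < 1000 nM in this assay, at which 1 of the 4 values shown sits.

Two cores make no rule for other cores in the series, and these data do not tell why the number rises.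

Open, on these data alone, is whether a longer chain, an amine or a carboxylic acid in place of oxolan-2-yl at the same place would give a step in the same direction on either core. Also open, as far as these compounds go, is how the other mirror form of the oxolan-2-yl group would compare.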